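Quinolinyl-oxadiazole piperidine ureas: aryl substituent swap

A few compounds are considered here, and "the series" means these few. Any claim that something is new, unique, unknown or untested is made for them only; others in the source may bear on it.

Measured so far:
compound 1, `CC(C)c1ccccc1NC(=O)N1CCC(c2nc(-c3ccc4ccccc4n3)no2)CC1`: 480 nM
compound 2, `Cn1c(-c2noc(C3CCN(C(=O)NC4CCCCC4)CC3)n2)nc2ccccc21`: 89 nM

In a functional assay on Shh Light II cells (Mus musculus) for inhibition, read by a luciferase reporter (a higher number here means a weaker inhibitor, a lower number a stronger inhibitor), compound 1 gives 480 nM, the highest of the two numbers in hand. Compound 2, which carries a different core and a cyclohexylamino urea, gives 89 nM in this assay; the two values lie beyond the scatter. Within the data shown here, compound 2 differs from compound 1 in more than one place, so no single step is drawn between them.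

Compound 3, `N#Cc1ccccc1NC(=O)N1CCC(c2nc(-c3ccc4ccccc4n3)no2)CC1`, is not yet measured. It differs from compound 1 in one place: cyano in place of isopropyl on an aromatic carbon, that is, 2-isopropylphenyl becomes 2-cyanophenyl, with the new group ortho to a large group. Among the measured compounds shown here, no measured pair shows this change, and the two measured compounds give no read on it. A small step in either direction, or none beyond the scatter, is expected; the estimated step is a 1.3-fold higher number from compound 1 to compound 3 (0.10 log units; within the scatter). For compound 3 in this assay the estimate is 600 nM, with a range from 150 nM to 2400 nM.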

Compound 3, half-maximal inhibitory concentration: 190 nM
Estimate against measurement, compound 3: 3.2-fold (0.50 log units) above; the measured number falls inside the stated range.
By their numbers in this assay, from the lowest: compound 2; then compound 3; then compound 1.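

In this assay, cyano in place of isopropyl on an aromatic carbon, ortho to a large group, gives a 2.5-fold lower number from compound 1 to compound 3 (0.40 log units; beyond the scatter). Among these compounds, this is the first single-place comparison, and it shows that this position responds to its substituent and that isopropyl is not needed to hold the number at the level of compound 1. No measured evidence in hand bears on why the number moves.

On these data alone, whether the step comes from the entry of cyano or from the departure of isopropyl stays open, and a hydrogen, a methoxy group or a chlorine atom at the same place would help separate the two. Compound 2 differs from these compounds in more than one place, so it gives no read on this position.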